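The compounds below may be only part of what the source reports. "The series", "measured", "known", "first", "only" and "open" are said of these compounds alone.

Working notes on the series. Compound 1 `CC(C)n1cc2c(C(N)=O)nc(N)nc2n1` gives in an assay on CHO cells for displacement of a labelled ligand from adenosine receptor A1 (Homo sapiens) (a higher number here means a weaker inhibitor, a lower number a stronger inhibitor), a value of 8200 nM. Compound 2 `CCOC(=O)c1nc(NC(=O)c2ccc(F)cc2)nc2nn(C)cc12` shares the core of compound 1 and is the starting point for the step taken here. In this assay compound 2 reaches only a limit, > 100000 nM, so no number stands for it. Of the two values shown, one sits at that limit (the limit of > 100000 nM in this assay, at which 1 of the 2 values shown sits). Compound 3 `CCOC(=O)c1nc(NC(=O)c2ccc(C)cc2)nc2nn(C)cc12` is the next member; it differs from compound 2 by methyl in place of fluoro on an aromatic carbon. Going by the values given here, no measured step between compounds is available to gauge such an exchange. With compound 2 at the limit > 100000 nM, a step of no more than the scatter is expected, a step that the limit leaves unreadable from compound 2 to compound 3. For compound 3 in this assay the estimate is 150000 nM, with a range from 50000 nM to 500000 nM, and most likely the readout is again only a limit.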

Compound 3, inhibition constant: > 100000 nM
Compound 3 was reported as a limit (the forecaster's own chance of this, stated with the estimate: 80%); the middle value lies beyond the limit too.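

Compound 2 and compound 3 are each reported only as a limit in this assay, so no step can be read between them: the limit of > 100000 nM in this assay, at which 2 of the 3 values shown sit.

The compounds shown leave open whether methyl in place of fluoro on an aromatic carbon shifts the value in this assay at all.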